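Moving the Thiophene Attachment in a Cytotoxicity Test

A few compounds are considered here, and "the series" means these few. Any claim that something is new, unique, unknown or untested is made for them only; others in the source may bear on it.

In an ADME assay on Huh-7 cells (Homo sapiens) for cytotoxicity, with a stated time of 72 h (a higher number here means that more compound is tolerated, a lower number that less compound is tolerated), compound 1 `CS(=O)(=O)Nc1ccc2c(c1)S(=O)(=O)N=C(c1c(O)c(-c3ccsc3)nn(CCC3CC3)c1=O)N2` gives > 1000 nM as a limit of the assay, not a number. Compound 2 `CC(C)CCn1nc(C2CCC2)c(O)c(C2=NS(=O)(=O)c3cc(NS(C)(=O)=O)ccc3N2)c1=O` gives > 33000 nM in this assay as another limit. Neither compound has an exact value, so compound 1 can only be placed on one side of its limit.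

Compound 3 `CS(=O)(=O)Nc1ccc2c(c1)S(=O)(=O)N=C(c1c(O)c(-c3cccs3)nn(CCC3CC3)c1=O)N2` has the same atoms as compound 1, joined differently: thiophen-2-yl in place of thiophen-3-yl on an aromatic carbon with the rest of the structure unchanged. Among the measured compounds shown here, no measured pair shows what such a swap does in this assay here. The expected step that the limit leaves unreadable from compound 1 to compound 3 is modest and upward, an estimate that reflects how compound 1 is known only as the limit > 1000 nM and not as a number. For compound 3 the estimated value is 3000 nM with an expected range from 1000 nM to 33000 nM in this test.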

Compound 3, half-maximal cytotoxic concentration: > 33000 nM
Compound 3 was reported as a limit; the forecaster's own chance of this, stated with the estimate: 75%; middle value at least 11-fold (1.04 log units) from the limit.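

Compound 1 gives > 1000 nM, a limit and not a number. Compound 3 gives > 33000 nM, also a limit, so no step can be read between these two compounds. Going by these compounds, whether thiophen-2-yl in place of thiophen-3-yl changes the result in this assay stays open.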